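Chloro-fluoro substitution on the aryl of compound 1

The source may hold more compounds than are shown below. What is called first, only, known or untested is meant among the compounds shown, and "the series" means these compounds.

Measured so far:
compound 1, `COc1cc2c(Oc3ccc(NC(=O)c4nn(-c5ccccc5)cc(C)c4=O)cc3)ccnc2cc1OCCCCCCC(=O)NO`: 420 nM
compound 2, `COc1cc2c(Oc3ccc(NC(=O)c4nn(-c5ccccc5C)ccc4=O)cc3)ccnc2cc1OCCCCCC(=O)NO`: 3920 nM

Both compounds were tested in a functional assay on A549 cells (Homo sapiens) for inhibition, read by MTT assay, with a stated time of 72 h; on this read-out higher numbers stand for weaker inhibition and lower numbers for stronger inhibition. Compound 1 gives 420 nM and holds the lowest number of the two; compound 2, with 3920 nM, stands clearly higher, beyond the usual scatter. Among the compounds with values here, compound 2 differs from compound 1 in more than one place, so no single-point step can be drawn between them, and the gap is recorded only as the two values show it.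

The next compound in the series is compound 3, `COc1cc2c(Oc3ccc(NC(=O)c4nn(-c5ccc(F)c(Cl)c5)cc(C)c4=O)cc3)ccnc2cc1OCCCCCCC(=O)NO`. It differs from compound 1 in one place only: 3-chloro-4-fluorophenyl in place of phenyl on an aromatic nitrogen. No measured pair in this series reports a change of this kind, so there is no shown step to lean on. Given that compound 1 already gives 420 nM, the expectation is that the substitution leaves the number roughly where it is or lowers it by a small amount, a step of a 1.4-fold lower number from compound 1 to compound 3 (0.15 log units; within the scatter) that may well sit within the scatter. Compound 3 is therefore estimated at 300 nM, with a range from 100 nM to 1000 nM.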

Compound 3, half-maximal inhibitory concentration: 380 nM
The estimate for compound 3 lay 1.3-fold (0.10 log units) below the measured number, within the range that was stated.
By their numbers in this assay, from the lowest: compounds 3 and 1 (each within the scatter of the next); then compound 2.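

In this assay, within the data shown here, the first single-point step at the aryl on the aromatic nitrogen reads a 1.1-fold lower number from compound 1 to compound 3 (0.04 log units; within the scatter) and comes from placing 3-chloro-4-fluorophenyl where compound 1 carries phenyl. This position therefore accepts both halogens together, with the larger group leaving the number within the scatter, so this change gives no measurable separation between compound 1 and compound 3 on this read-out. No measurement shown gives a reason for this result.

The compounds shown leave open whether chloro alone or fluoro alone would also stay within the scatter of compound 1, and whether an amine, a carboxylic acid or a longer chain on this phenyl would move the number beyond it. From the compounds shown here alone, the step has also been read only with the chain of compound 1 and only in this assay, so its size with a shorter chain, as carried by compound 2, remains unknown.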